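From a hydroxylated chain to oxan-3-yl

The source may hold more compounds than are shown below. What is called first, only, known or untested is meant among the compounds shown, and "the series" means these compounds.

Measured so far in a functional assay on DU-145 cells (Homo sapiens) for cytotoxicity, read by MTT assay (a lower number here means a stronger inhibitor, a higher number a weaker inhibitor), for the series:
- compound 1 `CCC(C)(O)CC(=O)O[C@H](CC=C(C)C)C1=CC(=O)c2c(O)ccc(O)c2C1=O` gives 16000 nM
- compound 2 `CCCCC(C)(O)CC(=O)O[C@H](CC=C(C)C)C1=CC(=O)c2c(O)ccc(O)c2C1=O` gives 76500 nM

Compound 2 at 76500 nM holds the higher number of the two. Compound 3 `CC(C)=CC[C@@H](OC(=O)C1CCCOC1)C1=CC(=O)c2c(O)ccc(O)c2C1=O` has oxan-3-yl in place of 2-hydroxy-2-methylhexyl on a carbonyl carbon. For the measured compounds named here, only one measured step bears on this change. Since a 4.8-fold higher number from compound 1 to compound 2 (0.68 log units; beyond the scatter) came with ethyl in place of hydrogen on that chain, losing the chain in compound 3 is expected to give a lower number by a similar modest size. Going by the values given here, no measured compound carries this ring, so the expectation is loose. The estimated step is a 3.8-fold lower number from compound 2 to compound 3 (0.58 log units; beyond the scatter) in this assay for this change. In this assay compound 3 is estimated at 20000 nM with an expected range from 6000 nM to 65000 nM for the measurement.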

Compound 3, half-maximal inhibitory concentration: 29700 nM
For compound 3 the middle estimate is 1.5-fold (0.17 log units) below the measured one, and the stated range covers the measured number.
By their numbers in this assay, from the lowest: compounds 1 and 3 (each within the scatter of the next); then compound 2.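

In this assay, the carbonyl carbon carries a ring as well as an open chain: oxan-3-yl, which has no hydrogen-bond donor, gives a 2.6-fold lower number from compound 2 to compound 3 (0.41 log units; beyond the scatter). Against the shorter chain, the same ring gives a 1.9-fold higher number from compound 1 to compound 3 (0.27 log units; within the scatter), so a hydroxylated chain is not needed to match compound 1 here. No supporting data bear on why the numbers fall this way. The compounds shown leave open whether the ring oxygen matters, which a plain cyclohexyl group would test, and whether a piperidine ring, with its amine, would serve on this carbonyl carbon.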